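The source may report more compounds than this note shows. Statements on the series, on what has been measured and on what is new or still open speak of the compounds shown alone.

Measured compounds:

Compound 1, `Cc1ccc(/C=C/C(=O)c2ccccc2NC(=O)NS(=O)(=O)c2ccc(C)cc2)cc1`, in an ADME assay on the whole organism for cytotoxicity, with Artemia salina as the target, with a stated time of 24 h (on this read-out higher numbers stand for an effect only at larger amounts of compound and lower numbers for an effect already at smaller amounts), gives 15.3 ug/mL.
Compound 2, `COc1ccc(/C=C/C(=O)c2ccccc2NC(=O)NS(=O)(=O)c2ccc(C)cc2)cc1`, gives 28.1 ug/mL.
Compound 3, `CCOc1cc(/C=C/C(=O)c2ccccc2NC(=O)NS(=O)(=O)c2ccc(C)cc2)ccc1O`, gives 19.2 ug/mL.

All three share one core and differ only in the aromatic group at the end of the double-bonded chain. Compound 3 sits between the other two: the step of a 1.3-fold higher number from compound 1 to compound 3 (0.10 log units; within the scatter) and the step of a 1.5-fold lower number from compound 2 to compound 3 (0.17 log units; within the scatter) are both within the scatter, so the three numbers cannot be told apart with confidence. The step of a 1.8-fold higher number from compound 1 to compound 2 (0.26 log units; within the scatter) is likewise within the scatter.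

Compound 4, `Cc1ccc(S(=O)(=O)NC(=O)Nc2ccccc2C(=O)/C=C/C=C/c2ccccc2)cc1`, has not yet been measured. It differs from compound 3 as follows: 2-phenylethenyl in place of 3-ethoxy-4-hydroxyphenyl on a double-bonded chain carbon bound to a double-bonded chain carbon. The change sits at the same place as the two measured swaps, and both of those, a 1.3-fold higher number from compound 1 to compound 3 (0.10 log units; within the scatter) and a 1.5-fold lower number from compound 2 to compound 3 (0.17 log units; within the scatter), stayed within the scatter. On that basis no step beyond the scatter is expected from compound 3 to compound 4, though the new group extends the chain and carries no donors or acceptors, which the measured swaps did not test. The expected step is a 1.0-fold higher number from compound 3 to compound 4 (0.02 log units; within the scatter). For compound 4 the estimate in this assay is 20 ug/mL, with a range from 8 ug/mL to 50 ug/mL.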

Compound 4, concentration for half-maximal effect: 18.2 ug/mL
Compound 4: middle estimate off by 1.1-fold (0.04 log units), on the high side; the measured number falls inside the stated range.
By their numbers in this assay, from the lowest: compounds 1, 4, 3 and 2 (each within the scatter of the next).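

Among the compounds shown here, at this place, on a double-bonded chain carbon bound to a double-bonded chain carbon, the earlier compounds only exchanged one substituted phenyl group for another, whereas 2-phenylethenyl brings in a double bond outside aromatic rings. In this assay this different kind of group stays within the scatter of all three earlier compounds, with a 1.1-fold lower number from compound 3 to compound 4 (0.02 log units; within the scatter) and a 1.5-fold lower number from compound 2 to compound 4 (0.19 log units; within the scatter) and also a 1.2-fold higher number from compound 1 to compound 4 (0.08 log units; within the scatter) as the steps. Compound 4 also gives up the hydrogen-bond donor and acceptors of the 3-ethoxy-4-hydroxyphenyl group of compound 3 without any step beyond the scatter, and nothing shown accounts for how little the number responds at this place.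

What the four compounds leave open is whether any group at this place can produce a step beyond the scatter, for example an amine or a carboxylic acid on the aromatic ring, or a longer chain of alternating double bonds. They also leave open how the number responds to changes elsewhere on the shared core, such as replacing the 4-methylphenyl group on the sulfonyl end with a simple methyl.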